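Three sulfonamides at the limit, and a fourth to come

The source may report more compounds than this note shows. Statements on the series, on what has been measured and on what is new or still open speak of the compounds shown alone.

Compound 2 `COc1ccc(Cl)cc1S(=O)(=O)Nc1ccc(-c2nc3ccccc3o2)cc1` was tested in an assay on cells for inhibition of HSP60/HSP10 (Homo sapiens), with a stated time of 60 min (on this read-out lower numbers stand for stronger inhibition and higher numbers for weaker inhibition), and gave only a limit, > 100000 nM. The same holds for compound 1 `Cc1ccccc1S(=O)(=O)Nc1ccc2oc(-c3ccccc3)nc2c1`, which in this assay gives > 100000 nM. Compound 3 `O=S(=O)(Nc1ccc2oc(-c3ccccc3)nc2c1)c1ccccc1C(F)(F)F` likewise returns the limit > 100000 nM in this assay. Hence the step that the two limits leave unreadable from compound 1 to compound 3 cannot be read, and compound 2 stands, like the others, at the limit described by the limit of > 100000 nM in this assay, at which 3 of the 3 values shown sit. Compound 4 `Cc1ccc(S(=O)(=O)Nc2ccc(-c3nc4ccccc4o3)cc2)cc1` differs from compound 2 by 4-methylphenyl in place of 5-chloro-2-methoxyphenyl on a sulfonyl sulfur. Within the data shown here, no measured step bears on this change, since every value shown is a limit. With three limits and no readable step, compound 4 is expected to remain at the limit as well, the expected step being a number no higher from compound 2 to compound 4 (the limit leaves the size open). For compound 4 the estimate is 100000 nM, with a range from 30000 nM to 300000 nM.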

Compound 4, half-maximal inhibitory concentration: > 100000 nM
Compound 4: a limit, no number; the forecaster's own chance of this, stated with the estimate: 85%; the middle value lies on the limit itself.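

Compound 2 and compound 4 both give only a limit, not a number, and the step between them cannot be read. The compounds shown leave open whether any group on the sulfonyl sulfur would yield a readable number.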